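A few compounds are considered here, and "the series" means these few. Any claim that something is new, unique, unknown or untested is made for them only; others in the source may bear on it.

Measured so far:
Compound 1, `CN(C(=O)NCCCOc1ccc2nc(O)ccc2c1)C1CCCCC1`, gives 21%.
Compound 2, `O=C(NCCCOc1ccc2nc(O)ccc2c1)N(C1CCCCC1)C1CC1`, gives 100%.

Going by the values given here, in a functional assay on the whole organism for inhibition, with Mus musculus as the target, at a dose of 30 mg/kg by the oral route (a lower number here means less inhibition, a higher number more inhibition at the dose given (going by the name of the read-out)), compound 2 holds the highest of the two measured numbers, and the single measured step, a number 79 percentage points higher from compound 1 to compound 2 (beyond the scatter), lies beyond the scatter. Compound 3, `O=C(NCCCOc1ccc2nc(O)ccc2c1)N(C1CC1)[C@@H]1CCC[C@H]1O`, differs from compound 2 by 2-hydroxycyclopentyl in place of cyclohexyl on an amide-type nitrogen. Among the compounds with values here, the one measured step altered a different group on that nitrogen, so no measured step bears on this change. With nothing to guide it, compound 3 is expected to show a modest fall, a number 30 percentage points lower from compound 2 to compound 3 (beyond the scatter), with a wide range. Compound 3 is therefore estimated at 70%, between 30% and 100%.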

Compound 3, a percentage reported as inhibition, in the whole organism at one dose (the size of the read-out at that dose, not a potency): 67%
The estimate for compound 3 lay 3 percentage points above the measured number; the range from low to high includes it.
By their numbers in this assay, from the lowest: compound 1; then compound 3; then compound 2.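

On this amide-type nitrogen, the cyclohexyl also matters in this assay: replacing it with 2-hydroxycyclopentyl gives a large change (a number 33 percentage points lower from compound 2 to compound 3 (beyond the scatter)). The earlier step varied only the other group on this nitrogen, so both groups now bear on the read-out. Nothing available explains this loss.

As far as these compounds go, two things change together here, the ring size and the added hydroxyl, and their separate contributions remain open. Also open, from the compounds shown here alone, is how an amine or a carboxylic acid in place of that hydroxyl would behave.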